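This account rests on a few compounds, and the source may have more. Where it says the series, first, only, none or still open, it means among the compounds named here.

In a physicochemical assay for lipophilicity, read by HPLC, at pH 7.5 (on this read-out lower numbers stand for lower lipophilicity and higher numbers for higher lipophilicity), compound 1 (`CCc1cc(CC)n2nc(-c3ccc(OC)cc3)c(CC(=O)N(C)C)c2n1`) gives 2.47. Compound 2 (`CCc1cc(CC)n2nc(-c3ccc(OC)cc3)c(CC(=O)N(C(C)CC)C(C)CC)c2n1`) gives 3.75, the higher of the two numbers and clearly beyond the scatter from compound 1. Compound 3 (`CCc1cc(CC)n2nc(-c3ccc(OC)cc3)c(CC(=O)N3CCC3)c2n1`) has not yet been measured in this assay. It differs from compound 2 as follows: azetidin-1-yl in place of bis(sec-butyl)amino on a carbonyl carbon. In words, azetidin-1-yl stands in place of bis(sec-butyl)amino on a carbonyl carbon. Going by the values given here, only one measured step bears on this change: a number 1.28 log units higher from compound 1 to compound 2 (beyond the scatter), a large step beyond the scatter, with bis(sec-butyl)amino in place of dimethylamino on a carbonyl carbon. The new change removes that same bis(sec-butyl)amino, so a large step down, close in size to that one, is expected. Among the compounds with values here, no measured compound carries azetidin-1-yl, which leaves the size uncertain. The expected step is a number 1.15 log units lower from compound 2 to compound 3 (beyond the scatter). Compound 3 is estimated at 2.6, within an expected range of 2.25 to 3.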

Compound 3, partition coefficient: 2.58
Compound 3: the middle estimate sits 0.02 log units above what was measured; measured number inside the range.
By their numbers in this assay, from the lowest: compounds 1 and 3 (each within the scatter of the next); then compound 2.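

In this assay, the group on this carbonyl carbon moves the number in both directions: azetidin-1-yl in place of bis(sec-butyl)amino gives a number 1.17 log units lower from compound 2 to compound 3 (beyond the scatter) and so undoes nearly all of the earlier rise. Azetidin-1-yl in place of dimethylamino gives a number 0.11 log units higher from compound 1 to compound 3 (within the scatter) so a closed four-membered ring and an open dimethylamino read alike here, and among these three groups only bis(sec-butyl)amino stands apart. Nothing available explains this result.

The compounds shown do not tell whether an intermediate open-chain group such as diethylamino would fall with compound 1 and compound 3 or nearer compound 2. They also leave open whether larger rings such as piperidin-1-yl or morpholin-4-yl would stay level with azetidin-1-yl.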